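This account rests on a few compounds, and the source may have more. Where it says the series, first, only, none or still open, it means among the compounds named here.

Measured in a functional assay on CHO cells for agonist activity at Free fatty acid receptor 1 (Homo sapiens), read by reporter gene assay; on this read-out higher numbers stand for larger maximal responses and lower numbers for smaller maximal responses:
- compound 1, `O=C(O)CCc1ccc(NCc2ccc(Cl)cc2)cc1`: 111%
- compound 2, `O=C(O)CCc1ccc(NCc2ccc(C(F)(F)F)cc2)cc1`: 133%
- compound 3, `CN(C)Cc1ccc(CNc2ccc(CCC(=O)O)cc2)cc1`: 12%

Compound 3 stands lowest of the three numbers in this assay. Its nearest neighbour is compound 1, the step of a number 99 percentage points lower from compound 1 to compound 3 (beyond the scatter) lying beyond the scatter; the furthest is compound 2, with a number 121 percentage points lower from compound 2 to compound 3 (beyond the scatter), also beyond the scatter. Both large drops are tied to the same change at the same aromatic carbon, so the (dimethylamino)methyl group goes with the small maximal response of compound 3.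

Compound 4, `COc1ccc(CNc2ccc(CCC(=O)O)cc2)cc1`, has not been measured. It differs from compound 3 as follows: methoxy in place of (dimethylamino)methyl on an aromatic carbon

Among the measured compounds shown here, no measured step involves methoxy, so none bears directly on this change. What does bear on it is that the two steps into compound 3, a number 99 percentage points lower from compound 1 to compound 3 (beyond the scatter) and a number 121 percentage points lower from compound 2 to compound 3 (beyond the scatter), both remove or install (dimethylamino)methyl and both are large; the step from compound 1 to compound 2, a number 22 percentage points higher from compound 1 to compound 2 (beyond the scatter), shows that the two other groups seen at this position give high, modestly different values. Taking (dimethylamino)methyl away is therefore expected to raise the maximal response substantially, though methoxy may not reach the level of chloro or trifluoromethyl. The expected step is a number 83 percentage points higher from compound 3 to compound 4 (beyond the scatter), upward and beyond the scatter. Compound 4 is estimated at 95%, with a range from 55% to 130%.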

Compound 4, largest response reached (reported as percent of maximum), in percent of the reference or control that the assay uses: 159%
Estimate against measurement, compound 4: 64 percentage points below; the measured number lies above the stated range.
By their numbers in this assay, from the lowest: compound 3; then compound 1; then compound 2; then compound 4.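

Within this assay, the position para to a large group tolerates more than the chloro and trifluoromethyl groups seen so far: with a number 147 percentage points higher from compound 3 to compound 4 (beyond the scatter), methoxy restores the response and goes beyond both of them, with a number 48 percentage points higher from compound 1 to compound 4 (beyond the scatter) and a number 26 percentage points higher from compound 2 to compound 4 (beyond the scatter). High maximal responses therefore do not depend on a halogen-bearing group here, and among the four groups shown only (dimethylamino)methyl in compound 3 gives a low response. The computed hydrogen-bond donor and acceptor counts and net charge are the same for methoxy and (dimethylamino)methyl, so those counts do not separate the two groups, and no measurement available here explains the gain from methoxy.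

The compounds shown leave open whether the low response of compound 3 goes with the amine nitrogen or with the greater heavy-atom count of its group. A methoxymethyl group, which keeps the chain but has an ether oxygen in place of the amine, and a dimethylamino group set directly on the ring would help separate these two readings.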